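Benzylsulfanyl variation in a chalcone-bearing triazolopyrimidine series

The source may report more compounds than this note shows. Statements on the series, on what has been measured and on what is new or still open speak of the compounds shown alone.

Measured so far in a functional assay on SW-620 cells (Homo sapiens) for cytotoxicity, read by MTT assay, with stated times of 4 h and 72 h, tested at 5 uM; on this read-out higher numbers stand for weaker inhibition and lower numbers for stronger inhibition:
compound 1, `Cc1cc(Nc2ccc(C(=O)/C=C/c3ccc4ccccc4c3)cc2)n2nc(SCc3ccccc3C(F)(F)F)nc2n1`, gives 1240 nM
compound 2, `Cc1cc(Nc2ccc(C(=O)/C=C/c3ccc4ccccc4c3)cc2)n2nc(SCc3cccc(C(F)(F)F)c3)nc2n1`, gives 2070 nM
compound 3, `Cc1cc(Nc2ccc(C(=O)/C=C/c3ccc4ccccc4c3)cc2)n2nc(SCc3ccccc3)nc2n1`, gives 300 nM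

Compound 1 stands second highest of the three numbers. Its nearest neighbour is compound 2, reached by a 1.7-fold higher number from compound 1 to compound 2 (0.22 log units; within the scatter), a change of position of the trifluoromethyl group that stays within the scatter. Its furthest neighbour is compound 3, reached by a 4.1-fold lower number from compound 1 to compound 3 (0.62 log units; beyond the scatter); the same removal of the trifluoromethyl group from compound 2 gives a 6.9-fold lower number from compound 2 to compound 3 (0.84 log units; beyond the scatter).

Compound 4, `Cc1cc(Nc2ccc(C(=O)/C=C/c3ccc4ccccc4c3)cc2)n2nc(SCc3ccc(Br)cc3)nc2n1`, has not been measured. Relative to compound 1 the change is 4-bromophenyl in place of 2-(trifluoromethyl)phenyl on a saturated chain carbon bound to a sulfur. Within the data shown here, no measured step introduces a bromine, so only indirect guidance exists: both trifluoromethyl-bearing compounds sit well above compound 3, and shifting that group between ring positions changed little. A bromine is a different substituent from a trifluoromethyl group, and the data cannot say whether it behaves like the trifluoromethyl group or like hydrogen at that ring. An intermediate outcome is therefore expected: compound 4 is estimated at 650 nM, in a range of 250 nM to 1700 nM, which amounts to an expected 1.9-fold lower number from compound 1 to compound 4 (0.28 log units; within the scatter), with considerable uncertainty in both directions.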

Compound 4, half-maximal inhibitory concentration: 370 nM
Estimate against measurement, compound 4: 1.8-fold (0.24 log units) above; measured number inside the range.
By their numbers in this assay, from the lowest: compounds 3 and 4 (each within the scatter of the next); then compounds 1 and 2 (each within the scatter of the next).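

In this assay, a substituent on the benzyl ring does not by itself carry the number upward: bromo in place of hydrogen gives a 1.2-fold higher number from compound 3 to compound 4 (0.09 log units; within the scatter) and stays within the scatter, which the trifluoromethyl compounds did not. The 4-bromobenzyl group also separates clearly from both trifluoromethyl-bearing benzyl groups, with a 3.4-fold lower number from compound 1 to compound 4 (0.53 log units; beyond the scatter) and a 5.6-fold lower number from compound 2 to compound 4 (0.75 log units; beyond the scatter) so that among these four compounds the higher numbers belong only to compound 1 and compound 2, and none goes against this. No measurement available here accounts for this split.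

Each step from a trifluoromethyl compound to compound 4 changes the group and its ring position together, so the contributions of the two remain unseparated. Going by these compounds, how a methoxy group, an amine or a carboxylic acid on this ring would read also remains open.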